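Trading the Fluorophenoxy Chain for a Plain Pentyl Tail

This account rests on a few compounds, and the source may have more. Where it says the series, first, only, none or still open, it means among the compounds named here.

Of the compounds shown here, three sharing one core have been tested in a functional assay on cells (Lymphocyte, Homo sapiens); a lower number here means a stronger inhibitor, a higher number a weaker inhibitor. Compound 1 `Nc1nc(N2CCN(C(=O)COc3ccc(Cl)cc3)CC2)c2nc(CCc3ccc(F)cc3)sc2n1` gives 4400 nM. Compound 2 `Nc1nc(N2CCN(C(=O)COc3ccc(Cl)cc3)CC2)c2nc(CCOc3ccc(F)cc3)sc2n1` gives 3540 nM. Within the data shown here, the step of a 1.2-fold lower number from compound 1 to compound 2 (0.09 log units; within the scatter) is the only measured step at the position now in question. Compound 3 `Nc1nc(N2CCN(C(=O)COc3ccc(F)cc3)CC2)c2nc(-c3ccc(F)cc3)sc2n1`, which differs from the other two at several positions, gives 70 nM. Among the three numbers compound 2 stands second highest, with compound 1 nearest and compound 3 furthest away.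

Compound 4 `CCCCCc1nc2c(N3CCN(C(=O)COc4ccc(Cl)cc4)CC3)nc(N)nc2s1` has not yet been measured in this assay. Compared with compound 2 the change is propyl in place of 4-fluorophenoxy on a saturated chain carbon, two bonds along the chain from an aromatic carbon. Among the measured compounds shown here, the one step at this place, exchanging an aromatic group for another aromatic group, stayed within the scatter; no measured step removes the ring from the saturated chain, so the data give little guidance. A small move toward a higher number, or none beyond the scatter, seems most likely. Compound 4 is therefore expected to give about 6000 nM, within a range from 2000 nM to 20000 nM. The step is estimated as a 1.7-fold higher number from compound 2 to compound 4 (0.23 log units; within the scatter).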

Compound 4, half-maximal inhibitory concentration: 690 nM
Beside the measured number, compound 4's estimate is 8.7-fold (0.94 log units) above it; measured number outside the range, below it.
By their numbers in this assay, from the lowest: compound 3; then compound 4; then compounds 2 and 1 (each within the scatter of the next).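

In this assay, the position turned out to respond to a change of another kind: propyl in place of 4-fluorophenoxy on a saturated chain carbon gave a 5.1-fold lower number from compound 2 to compound 4 (0.71 log units; beyond the scatter), a step beyond the scatter. Propyl in place of 4-fluorophenyl gave a 6.4-fold lower number from compound 1 to compound 4 (0.80 log units; beyond the scatter), also beyond the scatter, whereas the exchange of one aromatic group for another had given only a 1.2-fold lower number from compound 1 to compound 2 (0.09 log units; within the scatter), within it. Among these compounds, then, only the pentyl tail, which carries no ring, moves the number beyond the scatter, but no measurement here accounts for the gain.

The compounds shown leave open how the number depends on chain length, for instance with a shorter ethyl chain or a longer heptyl chain. They also leave open whether an amine or a carboxylic acid at the end of the pentyl chain would keep this gain.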